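Ethynyl in place of iodo: compound 3 to compound 4

This account rests on a few compounds, and the source may have more. Where it says the series, first, only, none or still open, it means among the compounds named here.

Measured in a functional assay on L1210 cells (Mus musculus) for inhibition; a higher number here means a weaker inhibitor, a lower number a stronger inhibitor:
- Compound 1 `C#CCN(Cc1ccc2nc(C)nc(O)c2c1)c1ccccc1`: > 6500 nM, a limit.
- Compound 2 `C#CCN(Cc1ccc2nc(C)nc(O)c2c1)c1cccc(Br)c1`: 1800 nM.
- Compound 3 `C#CCN(Cc1ccc2nc(C)nc(O)c2c1)c1cccc(I)c1`: > 5300 nM, a limit.

Compound 3 has no exact number in this assay, only the limit > 5300 nM. Of the three compounds, only compound 2 has a measured number. Bromo in place of hydrogen gave an at least 3.6-fold lower number from compound 1 to compound 2 (0.55 log units; beyond the scatter). Iodo in place of bromo gave an at least 2.9-fold higher number from compound 2 to compound 3 (0.46 log units; beyond the scatter). Iodo in place of hydrogen gave a step that the two limits leave unreadable from compound 1 to compound 3.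

The next compound, compound 4 `C#CCN(Cc1ccc2nc(C)nc(O)c2c1)c1cccc(C#C)c1`, changes this same position: ethynyl in place of iodo on an aromatic carbon. This puts ethynyl in place of iodo on an aromatic carbon. Going by the values given here, no measured step involves ethynyl, so the expectation rests on these two halogens alone, and they point in opposite directions. The case for a lower number leans on compound 2, which reached 1800 nM with a single group at this place. The step is expected to be modest and towards a lower number, though the limit on compound 3 leaves its size uncertain. The expected step is an at least 1.7-fold lower number from compound 3 to compound 4 (0.24 log units; that floor lies within the scatter). For compound 4 the estimated value is 3000 nM, with an expected range from 1000 nM to 9000 nM.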

Compound 4, half-maximal inhibitory concentration: > 2400 nM
Compound 4: only a limit was reported (the forecaster's own chance of this, stated with the estimate: 35%); the middle value lies beyond the limit too.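

In this assay compound 4 gives > 2400 nM, which is a limit and not a number. Ethynyl in place of bromo gives an at least 1.3-fold higher number from compound 2 to compound 4 (0.12 log units; that floor lies within the scatter), so the ethynyl group, like iodo, yields no exact value at this place, but the floor of this step does not separate it from bromo beyond the usual scatter. Going by these compounds alone, the steps to compound 4 from compound 1 and from compound 3 cannot be read, as each joins two limits, and compound 2 remains the only one of the four compounds with an exact value.

Going by these compounds, what stays open is where compound 4 truly lies beyond its limit, and with it whether ethynyl differs from bromo at this place at all. Also open, on these data alone, is whether chloro, a nitrile, an amine or a longer chain such as propynyl on the same aromatic carbon would give an exact value, and how any of them would stand against compound 2.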